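The source may report more compounds than this note shows. Statements on the series, on what has been measured and on what is new or still open speak of the compounds shown alone.

Measured so far:
compound 1, `C[C@H](CCO)CC[C@@H]1[C@@]2(C)CCCC(C)(C)[C@@H]2CC[C@@]1(C)O`, gives 15000 nM.
compound 2, `COC(=O)C[C@@H](C)CC[C@@H]1[C@@]2(C)CCCC(C)(C)[C@@H]2CC[C@@]1(C)O`, gives 5000 nM.

Both numbers come from a functional assay on RAW264.7 cells (Mus musculus) for inhibition, read by Griess assay, with stated times of 30 min and 24 h; on this read-out higher numbers stand for weaker inhibition and lower numbers for stronger inhibition. Going by the values given here, compound 2 stands lowest of the two values, and its separation from compound 1 is the single measured step, a 3.0-fold lower number from compound 1 to compound 2 (0.48 log units; beyond the scatter), which is described as beyond the scatter but modest. Compound 3, `C[C@H](CC=O)CC[C@@H]1[C@@]2(C)CCCC(C)(C)[C@@H]2CC[C@@]1(C)O`, has not yet been measured. It differs from compound 2 in one place: hydrogen in place of methoxy on a carbonyl carbon. The carbonyl that entered with compound 2 is kept, while the methoxy that came with it is removed, so compound 3 sits between compound 1 and compound 2 in what its chain end carries. Among the compounds with values here, only the step from compound 1 to compound 2 bears on this change, and it was modest. The expectation is therefore a step back toward the number of compound 1, a 1.6-fold higher number from compound 2 to compound 3 (0.20 log units; within the scatter), of a size that may not clearly exceed the scatter. Compound 3 is estimated to give 8000 nM in this assay, with a range from 3000 nM to 20000 nM.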

Compound 3, half-maximal inhibitory concentration: > 50000 nM
Compound 3: a limit, no number; the forecaster's own chance of this, stated with the estimate: 10%; middle value at least 6.2-fold (0.79 log units) from the limit.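

In this assay compound 3 returns a limit and not a number: the limit of > 50000 nM in this assay, at which 1 of the 3 values shown sits.

Even as a limit it can be read in one direction. Putting hydrogen in place of methoxy on the carbonyl carbon gives an at least 10-fold higher number from compound 2 to compound 3 (1.00 log units; beyond the scatter) and is the largest step seen at this chain end, while setting formyl in place of hydroxymethyl gives an at least 3.3-fold higher number from compound 1 to compound 3 (0.52 log units; beyond the scatter). So compound 3 does not fall between the other two: keeping the carbonyl is not enough to keep the stronger inhibition of compound 2, and the formyl end stands on the weak side of both the methoxycarbonyl end and the hydroxymethyl end.

These three compounds do not tell why the formyl end behaves so differently from the other two, and the size of both steps remains open beyond what is printed with them. Also open, from the compounds shown here alone, is whether a carboxylic acid, an amide or a longer chain at this same chain end would bring a lower number than that of compound 2, which is the lowest value so far.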